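Chloro-to-hydrogen swap on the pyrimidinone aryl of compound 1

A few compounds are considered here, and "the series" means these few. Any claim that something is new, unique, unknown or untested is made for them only; others in the source may bear on it.

Compound 1 `COc1ccc(-c2nc(C)c(C(=O)CSc3nc(-c4ccc(Cl)cc4)c(C#N)c(=O)[nH]3)s2)cc1` gives 92.7% in a functional assay on U-87MG ATCC cells for antiproliferative activity against U-87 MG (Homo sapiens), read by MTT assay, with a stated time of 48 h, tested at 10 uM; a lower number here means a stronger effect, a higher number a weaker effect of the compound at the concentration tested. Its two neighbours in the series both lie within the usual scatter of it: compound 2 `Cc1nc(-c2ccccc2)sc1C(=O)CSc1nc(-c2ccc(Cl)cc2)c(C#N)c(=O)[nH]1` gives 85.2%, a change of a number 7.5 percentage points lower from compound 1 to compound 2 (within the scatter), and compound 3 `Cc1nc(-c2ccc(Cl)cc2)sc1C(=O)CSc1nc(-c2ccc(Cl)cc2)c(C#N)c(=O)[nH]1` gives 98.4%, a change of a number 5.7 percentage points higher from compound 1 to compound 3 (within the scatter). Among the measured compounds shown here, the one step beyond the scatter is a number 13.2 percentage points higher from compound 2 to compound 3 (beyond the scatter), chloro in place of hydrogen on the aryl attached to the shared core.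

Compound 4 `COc1ccc(-c2nc(C)c(C(=O)CSc3nc(-c4ccccc4)c(C#N)c(=O)[nH]3)s2)cc1` differs from compound 1 by hydrogen in place of chloro on an aromatic carbon. For the measured compounds named here, no measured pair carries this exact change at this ring; the nearest guide is the step from compound 2 to compound 3, which runs in the opposite direction on the other aryl and was modest. Read in reverse, it suggests a small fall in this assay, though it may also stay within the scatter. Compound 4 is therefore expected to give 84%, within 72% to 96%, an estimated step of a number 8.7 percentage points lower from compound 1 to compound 4 (within the scatter).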

Compound 4, a percentage reported as activity, at one concentration (the size of the read-out at that concentration, not a potency): 90.9%
Estimate against measurement, compound 4: 6.9 percentage points below; the measured number falls inside the stated range.
By their numbers in this assay, from the lowest: compounds 2, 4, 1 and 3 (each within the scatter of the next, the first and the last beyond it).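

In this assay, 4-chlorophenyl to phenyl on the shared core gives a step of a number 1.8 percentage points lower from compound 1 to compound 4 (within the scatter). Among the compounds shown here, at this position on the core of compound 1, chloro and hydrogen therefore cannot be told apart, which the earlier compounds, all carrying the 4-chlorophenyl group here, could not show. The one step beyond the scatter, on the other aryl, also does not establish a real difference between the two places for this change: the same change on two cores in this assay, a number 13.2 percentage points higher (beyond the scatter) from compound 2 to compound 3 and a number 1.8 percentage points higher (within the scatter) from compound 4 to compound 1, 11.4 percentage points apart, within the scatter of two such steps

Only chloro and hydrogen are shown at this position, so it remains open whether any group placed here would move the read-out beyond the scatter. An amine or a carboxylic acid in place of the chloro, para to the large group, would test whether this position responds at all.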